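The source may report more compounds than this note shows. Statements on the series, on what has been measured and on what is new or still open speak of the compounds shown alone.

Compound 2 `CC(Sc1nc2c(cnn2C)c(=O)n1-c1ccccc1)c1cncnc1` is a sulfur-linked 1-(pyrimidin-5-yl)ethyl compound; in an assay on isolated protein for inhibition of aldehyde dehydrogenase 1A1 (Homo sapiens) (a higher number here means a weaker inhibitor, a lower number a stronger inhibitor), compound 2 gives 94 nM, the higher of the two numbers measured, with compound 1 `C[C@@H](Sc1nc2c(cnn2C)c(=O)n1-c1ccccc1)c1ccccc1` at 70 nM. Among the measured compounds shown here, the only measured step, a 1.3-fold higher number from compound 1 to compound 2 (0.13 log units; within the scatter), is small. Compound 3 `C[C@H](Sc1nc2c(cnn2C)c(=O)n1-c1ccccc1)c1ccccc1` carries the change (1-phenylethyl in place of 1-(pyrimidin-5-yl)ethyl on a sulfur), which brings back the 1-phenylethyl of compound 1, now with one defined stereocentre. For the measured compounds named here, that single measured step is the only guide, and it runs in the opposite direction; it suggests that this assay barely distinguishes the two groups, so a step no larger than the scatter is expected, though the defined stereocentre is untested by any measured pair and widens the uncertainty. Compound 3 is therefore expected to give about 150 nM, most likely between 40 nM and 600 nM, which means an expected step of a 1.6-fold higher number from compound 2 to compound 3 (0.20 log units; within the scatter).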

Compound 3, half-maximal inhibitory concentration: 1410 nM
Beside the measured number, compound 3's estimate is 9.4-fold (0.97 log units) below it; the whole stated range lies below it.
By their numbers in this assay, from the lowest: compounds 1 and 2 (each within the scatter of the next); then compound 3.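

In this assay, the largest step, a 20-fold higher number from compound 1 to compound 3 (1.30 log units; beyond the scatter), involves no change of group at all, so at this position the spatial arrangement matters as well as the group present: the fact that compounds 1 and 3 differ only in the configuration as drawn The drawn R form of the 1-phenylethyl compound therefore keeps the low number, while the S form loses most of its inhibition. The other step, a 15-fold higher number from compound 2 to compound 3 (1.18 log units; beyond the scatter), mixes two changes, the swap of ring and the gain of a defined stereocentre, so it cannot be read as an effect of the ring alone.

From the compounds shown here alone, how the separate R and S forms of the 1-(pyrimidin-5-yl)ethyl compound compare remains open. So does whether a 1-phenylpropyl group on the sulfur, with its longer chain, would show the same dependence on configuration.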